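The compounds below may be only part of what the source reports. "The series", "measured", "known", "first", "only" and "open" are said of these compounds alone.

Measured compounds:
compound 1, `CCNc1nc(-c2ccccc2)nc2c1nnn2Cc1ccccc1`: 91 nM
compound 2, `CCNc1nc(-c2ccccc2)nc2c1nnn2Cc1ccccc1F`: 11 nM
compound 3, `CCNc1nc(-c2ccccc2)nc2c1nnn2Cc1ccccc1C(F)(F)F`: "not determined" (no result reported)

In an assay on Cerebral cortex for displacement of a labelled ligand from adenosine receptor A1 (Bos taurus) (a lower number here means a stronger inhibitor, a higher number a weaker inhibitor), compound 1 gives 91 nM, and compound 2 gives 11 nM. Within the data shown here, the single step between measured compounds is an 8.3-fold lower number from compound 1 to compound 2 (0.92 log units; beyond the scatter). Compound 3 carries a trifluoromethyl group in place of the fluoro of compound 2, but for compound 3 no number was reported in this assay, so it stands nowhere on the scale shown; its place can only be guessed from compound 1 and compound 2, which bracket the range seen so far.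

Compound 4, `CCCCNc1nc(-c2ccccc2)nc2c1nnn2Cc1ccccc1C(F)(F)F`, differs from compound 3 by ethyl in place of hydrogen on a saturated chain carbon, two bonds along the chain from a nitrogen on an aromatic ring. Among the measured compounds shown here, no measured step touches the ethylamino group: the one step recorded, an 8.3-fold lower number from compound 1 to compound 2 (0.92 log units; beyond the scatter), concerns a different part of the molecule and therefore offers no direct guide to this change. Going by these compounds, with nothing to anchor it, the lengthening of the chain is expected to move the number in this assay by no more than the usual scatter, in no preferred direction, and the starting point for compound 3 itself is unknown. For compound 4 the estimate in this assay is therefore 30 nM, with a range from 5 nM to 200 nM.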

Compound 4, inhibition constant: 6.5 nM
For compound 4 the middle estimate is 4.6-fold (0.66 log units) above the measured one; the measured number falls inside the stated range.
By their numbers in this assay, from the lowest: compounds 4 and 2 (each within the scatter of the next); then compound 1.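

In this assay, among these compounds, compound 3 stands as "not determined" (no result reported) and compound 4 gives 6.5 nM, so no step from compound 3 to compound 4 can be read. The compounds shown leave open what ethylamino to butylamino does on its own, and what trifluoromethyl does in place of fluoro. No evidence at hand bears on this result.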